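Isothiocyanate chain length on the fluorinated aryl amide series

The compounds below may be only part of what the source reports. "The series", "measured", "known", "first", "only" and "open" are said of these compounds alone.

Measured compounds:
Compound 1 `CN(C)C(=O)c1cc2cnc(Nc3ccc(C(=O)NCCCCCN=C=S)cc3)nc2n1C1CCCC1`: 29.3%
Compound 2 `CN(C)C(=O)c1cc2cnc(Nc3ccc(C(=O)NCCCN=C=S)cc3F)nc2n1C1CCCC1`: 16.7%
Compound 3 `CN(C)C(=O)c1cc2cnc(Nc3ccc(C(=O)NCCCCN=C=S)cc3F)nc2n1C1CCCC1`: -7%

Compound 3 stands lowest of the three numbers in a functional assay on A549 cells (Homo sapiens) for inhibition, read by CCK-8 assay, with a stated time of 72 h, tested at 1 uM; a lower number here means a weaker effect, a higher number a stronger effect of the compound at the concentration tested. Among the compounds with values here, its nearest neighbour is compound 2, and the gap is the one measured step that bears here: a number 23.7 percentage points lower from compound 2 to compound 3 (beyond the scatter), a drop beyond the scatter on adding one chain carbon. Within the data shown here, compound 1, the furthest, differs from compound 3 in both the chain and the fluorine, so no single step is available; its value only shows that a five-carbon chain is compatible with an effect in this assay on the unfluorinated variant.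

Compound 4 `CN(C)C(=O)c1cc2cnc(Nc3ccc(C(=O)NCCCCCN=C=S)cc3F)nc2n1C1CCCC1` is not yet measured. Its change from compound 3 is a group of 4 heavy atoms (2 carbon, 1 nitrogen, 1 sulfur; no ring) in place of a group of 3 heavy atoms (1 carbon, 1 nitrogen, 1 sulfur; no ring), on a saturated chain carbon, four bonds along the chain from an amide-type nitrogen.

Among the measured compounds shown here, the only step of this kind, the one from compound 2 to compound 3, went downward. The value of compound 1, which carries the same chain as compound 4 but lacks the fluorine, points the other way. For the measured compounds named here, with only one step and one contrasting pair, the direction is uncertain; a modest rise is expected, a number 22 percentage points higher from compound 3 to compound 4 (beyond the scatter), within a wide range.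

Compound 4 is estimated at 15% in this assay, between -10% and 40%.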

Compound 4, a percentage reported as inhibition, at one concentration (the size of the read-out at that concentration, not a potency): -1.6%
Compound 4: the middle estimate sits 16.6 percentage points above what was measured; the measured number falls inside the stated range.
By their numbers in this assay, from the lowest: compounds 3 and 4 (each within the scatter of the next); then compound 2; then compound 1.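

In this assay, extending the chain on the fluorinated series gives a number 5.4 percentage points higher from compound 3 to compound 4 (within the scatter), so at this place, four bonds along the chain from an amide-type nitrogen, further lengthening does not bring back the number seen for the shortest chain. That separation is confirmed by a number 18.3 percentage points lower from compound 2 to compound 4 (beyond the scatter), which places both longer fluorinated chains apart from compound 2 in this series. Within the data shown here, the first comparison that isolates the ring substituent is a number 30.9 percentage points lower from compound 1 to compound 4 (beyond the scatter), in which fluoro in place of hydrogen on an aromatic carbon goes with the lower number when the chain is held constant.

No measurement available here accounts for either the chain or the fluoro result. Still open, as far as these compounds go, is whether the fluoro step has the same direction and size with the shorter chains of compound 2 and compound 3, and whether a longer chain, or an amine in place of the isothiocyanate, changes the number in this assay.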